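This account rests on a few compounds, and the source may have more. Where it says the series, first, only, none or still open, it means among the compounds named here.

Compound 3 `O=c1[nH]c(=O)n(C2C[C@@H](O)[C@@H](CO)O2)nc1C=C(Br)Br` shares its core with compound 1 `O=c1[nH]c(=O)n(C2C[C@@H](O)[C@@H](CO)O2)nc1/C=C/Br` and compound 2 `O=c1[nH]c(=O)n(C2C[C@@H](O)[C@@H](CO)O2)nc1/C=C(\F)Br`; the three differ only in the group on the aromatic carbon of that core. In a functional assay on Vero cells (Chlorocebus sabaeus) for cytotoxicity (on this read-out higher numbers stand for weaker inhibition and lower numbers for stronger inhibition), compound 1 gives 355 ug/mL. Compound 2 reaches only a limit of the assay, > 500 ug/mL, in this assay. Compound 3 likewise reaches only a limit, > 500 ug/mL, so its standing is known only as a floor, not as a number. The measured steps were an at least 1.4-fold higher number from compound 1 to compound 2 (0.14 log units; that floor lies within the scatter) and an at least 1.4-fold higher number from compound 1 to compound 3 (0.14 log units; that floor lies within the scatter), while the step that the two limits leave unreadable from compound 2 to compound 3 cannot be read. Among the compounds with values here, the new compound 4 `O=c1[nH]c(=O)n(C2C[C@@H](O)[C@@H](CO)O2)nc1-c1ccoc1` carries a change, (furan-3-yl in place of 2,2-dibromoethenyl on an aromatic carbon), that none of the measured steps covers, since a bromine-bearing chain is exchanged for an aromatic ring rather than for another chain. With two of the three values sitting at the limit, as shown by the limit of > 500 ug/mL in this assay, at which 2 of the 3 values shown sit, the measured steps give no direction for this change. Compound 4 is therefore expected to land near 400 ug/mL, within 150 ug/mL to 800 ug/mL. That estimate means a step of an at least 1.2-fold lower number from compound 3 to compound 4 (0.09 log units; that floor lies within the scatter), most likely again ending at the limit.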

Compound 4, concentration for 50% inhibition: 45 ug/mL
Beside the measured number, compound 4's estimate is 8.9-fold (0.95 log units) above it, outside the stated range (below it).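

In this assay, the group on this aromatic carbon can clearly change the result: replacing a bromine-bearing chain with furan-3-yl gives an at least 11-fold lower number from compound 3 to compound 4 (1.04 log units; beyond the scatter), an at least 11-fold lower number from compound 2 to compound 4 (1.04 log units; beyond the scatter) and a 7.9-fold lower number from compound 1 to compound 4 (0.90 log units; beyond the scatter). Among the three bromine-bearing chains, no readable step went beyond the scatter, so this is the first clear sign that cytotoxicity responds to a change at this position. Two of the new steps are only floors, because compound 2 and compound 3 each stand at a limit of the assay: the limit of > 500 ug/mL in this assay, at which 2 of the 4 values shown sit.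

The step between compound 2 and compound 3 still cannot be read. With furan-3-yl as the only ring shown here, it remains open whether phenyl would give a similar result, or whether an amine or a longer bromine-free chain would.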